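Methoxy on the Pyrazoline Phenyl: Expected Cytotoxicity

The compounds below may be only part of what the source reports. "The series", "measured", "known", "first", "only" and "open" are said of these compounds alone.

Compound 1 `COc1ccc(C2CC(c3ccccc3)=NN2C2=NC(=O)/C(=C3\C(=O)Nc4ccccc43)S2)cc1` gives 3350 nM in a functional assay on cells (Cancer cell lines, Homo sapiens) for cytotoxicity, read by sulforhodamine B assay, with a stated time of 48 h (on this read-out lower numbers stand for stronger inhibition of growth and higher numbers for weaker inhibition of growth), the highest of the two numbers measured; compound 2 `COc1ccc(C2CC(c3ccccc3)=NN2C2=NC(=O)/C(=C3\C(=O)Nc4ccc(Br)cc43)S2)cc1` gives 660 nM, and the step of a 5.1-fold lower number from compound 1 to compound 2 (0.71 log units; beyond the scatter) came from bromo in place of hydrogen on an aromatic carbon. Compound 3 `COc1ccc(C2=NN(C3=NC(=O)/C(=C4\C(=O)Nc5ccccc54)S3)C(c3ccc(OC)cc3)C2)cc1` differs from compound 1 by methoxy in place of hydrogen on an aromatic carbon. Going by the values given here, no measured step touches this ring; the bromo step sits elsewhere and does not bear on it. No change beyond the scatter is therefore expected, a 1.1-fold lower number from compound 1 to compound 3 (0.05 log units; within the scatter). Compound 3 is estimated at 3000 nM, between 1000 nM and 9000 nM.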

Compound 3, concentration for total growth inhibition: 100000 nM
Estimate against measurement, compound 3: 33-fold (1.52 log units) below; measured number outside the range, above it.
By their numbers in this assay, from the lowest: compound 2; then compound 1; then compound 3.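

The phenyl ring that changes in compound 3 is not a silent position: in this assay, methoxy on an aromatic carbon, para to a large group, gives a 30-fold higher number from compound 1 to compound 3 (1.47 log units; beyond the scatter). This step runs in the opposite direction to the bromo step, a 5.1-fold lower number from compound 1 to compound 2 (0.71 log units; beyond the scatter), which lies elsewhere on the molecule. Nothing available explains the loss of growth inhibition.

On these data alone, whether any group on this carbon has the same result, or methoxy alone, remains open; fluoro, hydroxy or an amine here would separate these cases. Also open, as far as these compounds go, is whether bromo would still lower the number in compound 3.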